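This account rests on a few compounds, and the source may have more. Where it says the series, first, only, none or still open, it means among the compounds named here.

Going by the values given here, the series is built on a shared core carrying a substituted cyclohexene ether, and the three measured members are compound 1 `COc1cc(/C=C/C(=O)/C=C(O)/C=C/c2ccc(O[C@H]3C=C(C)[C@@H](O)C[C@@H]3[C@@H](C)CCC=C(C)C)c(OC)c2)ccc1O`, compound 2 `COc1cc(/C=C/C(=O)/C=C(O)/C=C/c2ccc(O[C@H]3C[C@H]([C@@H](C)CCC=C(C)C)[C@@H](O)C=C3C)c(OC)c2)ccc1O` and compound 3 `COc1cc(/C=C/C(=O)/C=C(O)/C=C/c2ccc(O[C@H]3C[C@H]([C@@H](C)CCC=C(C)C)C=C[C@@]3(C)O)c(OC)c2)ccc1O`. In a functional assay on A549 cells (Homo sapiens) for cytotoxicity, read by crystal violet staining, with a stated time of 72 h (on this read-out lower numbers stand for stronger inhibition and higher numbers for weaker inhibition), compound 1 gives 30600 nM, compound 2 gives 61900 nM and compound 3 gives 35000 nM. Compound 3 therefore holds the second highest of the three numbers; its nearest neighbour is compound 1 and its furthest is compound 2, and both of those gaps lie within the usual scatter of this assay, so no order among the three can be read from these values.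

The unmeasured compound 4 `COc1cc(/C=C/C(=O)/C=C(O)/C=C/c2ccc(O[C@H]3C[C@H]([C@@H](C)CC(=O)C=C(C)C)C=C[C@@]3(C)O)c(OC)c2)ccc1O` differs from compound 3 in one place: (2-methylprop-1-en-1-yl)carbonyl in place of 3-methylbut-2-en-1-yl on a saturated chain carbon, two bonds along the chain from a saturated ring carbon. Among the compounds with values here, no step between measured compounds bears on this change, and the three measured values sit close together, so the author expects no move in this assay beyond the scatter, in either direction, with the step from compound 3 to compound 4 estimated at no change at the digits printed from compound 3 to compound 4 (within the scatter). On that basis compound 4 is expected to give about 35000 nM, with a range from 15000 nM to 80000 nM.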

Compound 4, half-maximal inhibitory concentration: 14300 nM
For compound 4 the middle estimate is 2.4-fold (0.39 log units) above the measured one; measured number below the stated range.
By their numbers in this assay, from the lowest: compound 4; then compounds 1, 3 and 2 (each within the scatter of the next, the first and the last beyond it).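

Replacing 3-methylbut-2-en-1-yl with (2-methylprop-1-en-1-yl)carbonyl on a saturated chain carbon, two bonds along the chain from a saturated ring carbon, gives a 2.4-fold lower number from compound 3 to compound 4 (0.39 log units; beyond the scatter) in this assay and is a modest move beyond the scatter. Going by these compounds alone, the earlier compounds offered no step that differed in one place, so only this pair shows that the number responds to a change at this position, and here the entering carbonyl group goes with the lower number. Nothing among the available data accounts for this step.

As far as these compounds go, whether the same change would give a similar step on the cores of compound 1 and compound 2 remains open. Also open, from the compounds shown here alone, is how an amine, a carboxylic acid or a longer chain at this position would compare with the (2-methylprop-1-en-1-yl)carbonyl group.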